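A 3-oxomorpholin-4-yl group on the shared core

A few compounds are considered here, and "the series" means these few. Any claim that something is new, unique, unknown or untested is made for them only; others in the source may bear on it.

In a physicochemical assay for lipophilicity, measured as octanol-water partition, at pH 7.4 (a lower number here means a more polar compound, a higher number a more lipophilic compound), compound 1 `O=C([C@H](O)CS(=O)(=O)c1ccc2cc(Cl)ccc2c1)N1CCC(N2CCCS2(=O)=O)CC1` gives 1.69 and compound 2 `O=C([C@H](O)CS(=O)(=O)c1ccc2cc(Cl)ccc2c1)N1CCC(N2CCCOC2=O)CC1` gives 1.67 with the two numbers within the scatter of each other. Compound 3 `O=C([C@H](O)CS(=O)(=O)c1ccc2cc(Cl)ccc2c1)N1CCC(N2CCOCC2=O)CC1` has not yet been measured. It differs from compound 2 by a group of 7 heavy atoms (4 carbon, 1 nitrogen, 2 oxygen; one six-membered non-aromatic ring with 2 hetero atoms) in place of a group of 7 heavy atoms (4 carbon, 1 nitrogen, 2 oxygen; one six-membered non-aromatic ring with 2 hetero atoms), on a saturated ring carbon on a saturated ring carbon of a six-membered non-aromatic ring with 1 nitrogen, three ring bonds from the ring nitrogen. The two have the same atoms, joined differently, and the group that enters is 3-oxomorpholin-4-yl. Among the measured compounds shown here, the one measured step that bears on this change is a number 0.02 log units lower from compound 1 to compound 2 (within the scatter) and it also exchanges one ring group for another on that saturated ring carbon. It is a single pair with a different ring on one side, so it offers only limited guidance. No step beyond the scatter is expected in this assay on this evidence. The estimated step is a number 0.17 log units lower from compound 2 to compound 3 (within the scatter) and no larger change is expected. For compound 3 the expected value is 1.5 with an estimated range from 1.2 to 1.8 on this scale.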

Compound 3, distribution coefficient: 1.85
Estimate against measurement, compound 3: 0.35 log units below; the whole stated range lies below it.
By their numbers in this assay, from the lowest: compounds 2, 1 and 3 (each within the scatter of the next).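

Notes on the saturated ring carbon three ring bonds from the ring nitrogen: in this assay, placing 3-oxomorpholin-4-yl there in place of a ring group with the same atoms, joined differently, gives a number 0.18 log units higher from compound 2 to compound 3 (within the scatter) and so separates this rearrangement of the ring from a step beyond the scatter. Measured against the five-membered non-aromatic ring group of compound 1, which holds sulfur, the same entering group gives a number 0.16 log units higher from compound 1 to compound 3 (within the scatter), so all three ring groups shown, in compound 1, compound 2 and compound 3, read within the scatter of one another in this assay. No evidence is available that gives a cause for these readings.

What a carboxylic acid or a primary amine on this saturated ring carbon would read in this assay stays open, as the three groups shown are all six- or five-membered non-aromatic rings with 2 hetero atoms. Also open, going by these compounds, is whether these ring groups would read as closely on any core other than the shared core, which is the only one covered here.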